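A few compounds are considered here, and "the series" means these few. Any claim that something is new, unique, unknown or untested is made for them only; others in the source may bear on it.

Working notes on the series. Compound 1 `Cc1cc(-c2sc(Cc3cccc(Cl)c3)nc2C)ccc1C(N)=O` and compound 2 `Cc1cc(-c2sc(Cc3ccccc3Cl)nc2C)ccc1C(N)=O` share a core and differ only in the aryl group on the benzylic carbon. For the measured compounds named here, in a functional assay on cells for agonist activity at G-protein coupled receptor 52 (Homo sapiens), read by AlphaScreen and cAMP accumulation, with a stated time of 30 min (a higher number here means that more compound is needed for the effect, a lower number that less compound is needed), compound 1 gives 130 nM, while compound 2 gives 3900 nM, the highest of the two numbers so far; the step of a 30-fold higher number from compound 1 to compound 2 (1.48 log units; beyond the scatter) is the only one recorded and lies well beyond the scatter. Compound 3 `Cc1cc(-c2sc(Cc3cc(F)cc(Cl)c3)nc2C)ccc1C(N)=O` is not yet measured. It differs from compound 2 by 3-chloro-5-fluorophenyl in place of 2-chlorophenyl on a saturated chain carbon bound to an aromatic carbon, returning the chlorine to the arrangement of compound 1 and adding a fluorine. The step from compound 1 to compound 2 bears directly on this, since the move from compound 2 to compound 3 reverses that change; a large drop in this assay is therefore expected, roughly undoing a 30-fold higher number from compound 1 to compound 2 (1.48 log units; beyond the scatter), with the added fluorine not expected to shift the number beyond the scatter. Compound 3 is expected to give 150 nM, between 50 nM and 500 nM, an estimated step of a 26-fold lower number from compound 2 to compound 3 (1.41 log units; beyond the scatter).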

Compound 3, half-maximal effective concentration: 25 nM
The estimate for compound 3 lay 6.0-fold (0.78 log units) above the measured number; the whole stated range lies above it.
By their numbers in this assay, from the lowest: compound 3; then compound 1; then compound 2.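

In this assay, fluoro in place of hydrogen on an aromatic carbon gives a 5.2-fold lower number from compound 1 to compound 3 (0.72 log units; beyond the scatter) and so shows that this ring can still be improved once the chlorine is in the arrangement of compound 1. The full change, 3-chloro-5-fluorophenyl in place of 2-chlorophenyl, gives a 160-fold lower number from compound 2 to compound 3 (2.19 log units; beyond the scatter) and combines the chlorine change with the added fluorine. Nothing at hand explains either step.

As far as these compounds go, whether the chlorine is needed at all remains open, as a plain phenyl or a 3-fluorophenyl would show. So does whether a nitrile, a methoxy group or a second chlorine could stand in place of the fluorine.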